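A few compounds are considered here, and "the series" means these few. Any claim that something is new, unique, unknown or untested is made for them only; others in the source may bear on it.

The read-out here is a functional assay on MCF7 cells (Homo sapiens) for inhibition; on this read-out higher numbers stand for weaker inhibition and lower numbers for stronger inhibition. Compound 1, with structure `CCOC(=O)c1ccc(NC(=O)N2CC2C#N)cc1`, is the larger of the two measured compounds; in this assay compound 1 gives 2100 nM. Compound 2, with structure `N#CC1CN1C(N)=O`, keeps the small ring bearing the nitrile but has an unsubstituted amide-type nitrogen. For compound 2 the result in this assay is > 54000 nM, which is a limit of the assay rather than a measured number, as recorded in the limit of > 54000 nM in this assay, at which 1 of the 2 values shown sits. Compound 2 thus stands at the weak end of what has been seen, without an exact value.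

Compound 3, with structure `CNC(=O)N1CC1C#N`, is not yet measured. It differs from compound 2 by methyl in place of hydrogen on an amide-type nitrogen. For the measured compounds named here, no step between two measured compounds is available to guide the size of this change; the only comparison is that compound 1, carrying a much larger group on that nitrogen, reaches 2100 nM. A single methyl is expected to move the result little, if at all, beyond the usual scatter, so an at least 1.0-fold lower number from compound 2 to compound 3 (0.03 log units; that floor lies within the scatter) is estimated to be small. Compound 3 is therefore expected to come out near 50000 nM, within a range from 15000 nM to 150000 nM, with a fair chance that only a limit is reported again.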

Compound 3, half-maximal inhibitory concentration: 17000 nM
The estimate for compound 3 lay 2.9-fold (0.47 log units) above the measured number; low and high end bracket the measured number.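

In this assay, putting methyl in place of hydrogen on the amide-type nitrogen gives an at least 3.1-fold lower number from compound 2 to compound 3 (0.50 log units; beyond the scatter). This size is a minimum rather than an exact figure, because compound 2 stands at a limit of the assay: the limit of > 54000 nM in this assay, at which 1 of the 3 values shown sits. For the compounds shown here, the earlier compounds showed only that a very large group on this nitrogen could go with a measured value, whereas this step shows that one added carbon, with no ring and no hydrogen-bond donor or acceptor, already moves the read-out beyond the usual scatter, with compound 3 at 17000 nM and compound 1 at 2100 nM.

The compounds shown leave open how the read-out changes across the wide gap in size between methyl and the group on compound 1, for example with an ethyl group, a longer chain or an unsubstituted phenyl group on the same nitrogen. They also do not tell how far the true step from hydrogen to methyl extends, or whether a second methyl on this nitrogen, which would remove the amide hydrogen, would push the number lower or higher.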